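This account rests on a few compounds, and the source may have more. Where it says the series, first, only, none or still open, it means among the compounds named here.

Measured so far in an ADME assay for permeability, using PAMPA, at pH 7.4; a lower number here means that the compound crosses the layer more slowly, a higher number that the compound crosses the layer faster:

compound 1, `COc1ccc2[nH]c(C)c(Br)c(=O)c2c1`, gives 16.7 10^-6 cm/s
compound 2, `Cc1[nH]c2ccc(Cl)cc2c(=O)c1Br`, gives 87.7 10^-6 cm/s
compound 3, `COc1ccc2[nH]c(C)c(Cc3ccccc3)c(=O)c2c1`, gives 188 10^-6 cm/s

Compound 3 gives the highest of the three numbers in this assay; its distance to compound 2 and to compound 1 is beyond the scatter in each case. The two cores present differ by one change, computed from the structures of compound 1 and compound 3: benzyl in place of bromo on an aromatic carbon. That change made the step of an 11-fold higher number from compound 1 to compound 3 (1.05 log units; beyond the scatter).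

Within the core of compound 1, one change has been measured: chloro in place of methoxy on an aromatic carbon. It made the step of a 5.3-fold higher number from compound 1 to compound 2 (0.72 log units; beyond the scatter).

Compound 4, `Cc1[nH]c2ccc(Cl)cc2c(=O)c1Cc1ccccc1`, is not yet measured in this assay. It carries the same change from compound 3: chloro in place of methoxy on an aromatic carbon. The place line is the same word for word as in the change from compound 1 to compound 2, so this is the same change, carried out on the other core.

For the measured compounds named here, the step expected from compound 3 to compound 4 in this assay is a 1.7-fold higher number from compound 3 to compound 4 (0.23 log units; within the scatter), smaller than the earlier one because compound 3 already stands at 188 10^-6 cm/s and the pair of compound 1 and compound 2 is the only measured instance of this change. For compound 4 the expected number in this assay is 320 10^-6 cm/s, estimated between 160 10^-6 cm/s and 650 10^-6 cm/s.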

Compound 4, apparent permeability: 415 10^-6 cm/s
The estimate for compound 4 lay 1.3-fold (0.11 log units) below the measured number, and the stated range covers the measured number.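

In this assay, chloro in place of methoxy on an aromatic carbon again gave a step in the same direction on the second core, a 2.2-fold higher number from compound 3 to compound 4 (0.34 log units; beyond the scatter). Set beside the earlier instance, the two steps agree in direction and their sizes cannot be told apart: the same change on two cores in this assay, a 5.3-fold higher number (0.72 log units; beyond the scatter) from compound 1 to compound 2 and a 2.2-fold higher number (0.34 log units; beyond the scatter) from compound 3 to compound 4, 2.4-fold (0.38 log units) apart, within the scatter of two such steps. This supports carrying the change between the core of compound 1 and the core of compound 3 as a step of the same sign, but it rests on two pairs only, gives no rule for any other core, and does not show what in the change produces the step.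

Still open, from the compounds shown here alone, is how an amine or a carboxylic acid on the same aromatic carbon would stand against chloro and methoxy in this assay. Also open, going by these compounds, is whether a longer chain in place of benzyl would leave the number near that of compound 4, and whether the step from methoxy to chloro would keep its direction on a third core.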